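This account rests on a few compounds, and the source may have more. Where it says the series, first, only, none or still open, it means among the compounds named here.

In a functional assay on PC-12 cells (Rattus norvegicus) for cytotoxicity, read by MTT assay, with stated times of 2 h and 24 h, tested at 5 uM (a lower number here means a weaker effect, a higher number a stronger effect of the compound at the concentration tested), the three measured compounds stand as follows:

compound 1 `Oc1cc(C(F)(F)F)ccc1-c1nc(-c2ccccc2O)n(-c2ccc(Br)cc2)n1`: 89.8%
compound 2 `Oc1cc(C(F)(F)F)ccc1-c1nc(-c2ccccc2O)n(-c2ccc(OC(F)(F)F)cc2)n1`: 84.9%
compound 3 `Cc1ccc(-n2nc(-c3ccc(C(F)(F)F)cc3O)nc2-c2ccccc2O)c(C)c1`: 93.3%

Compound 2 holds the lowest of these three numbers, but neither neighbour is clearly apart from it: the step of a number 4.9 percentage points lower from compound 1 to compound 2 (within the scatter) and the step of a number 8.4 percentage points higher from compound 2 to compound 3 (within the scatter) both sit within the scatter, so the three compounds cannot be ordered on these data.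

Compound 4 `Oc1cc(C(F)(F)F)ccc1-c1nc(-c2ccccc2O)n(-c2cc(F)cc(F)c2)n1` has not yet been tested. It differs from compound 2 in one place: 3,5-difluorophenyl in place of 4-(trifluoromethoxy)phenyl on an aromatic nitrogen. Within the data shown here, two measured steps bear on this change, since both swap the group on the aromatic nitrogen of the shared core: a number 8.4 percentage points higher from compound 2 to compound 3 (within the scatter) and a number 3.5 percentage points higher from compound 1 to compound 3 (within the scatter), each within the scatter. Among the measured compounds shown here, the only other step, a number 4.9 percentage points lower from compound 1 to compound 2 (within the scatter), is also within the scatter. With every measured change at this position leaving the number essentially unmoved, compound 4 is expected to show no step beyond the scatter in this assay, that is, an expected a number 2.1 percentage points higher from compound 2 to compound 4 (within the scatter). The estimate for compound 4 is therefore 87%, within a range from 75% to 97%.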

Compound 4, a percentage reported as activity, at one concentration (the size of the read-out at that concentration, not a potency): 100%
Beside the measured number, compound 4's estimate is 13 percentage points below it, outside the stated range (above it).
By their numbers in this assay, from the lowest: compounds 2, 1, 3 and 4 (each within the scatter of the next, the first and the last beyond it).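

In this assay, the group on the aromatic nitrogen now yields steps beyond the scatter, which no earlier change at this position did: 3,5-difluorophenyl gives a number 15.1 percentage points higher from compound 2 to compound 4 (beyond the scatter) and a number 10.2 percentage points higher from compound 1 to compound 4 (beyond the scatter). The change is not clear against every group, however, since the remaining comparison gives a number 6.7 percentage points higher from compound 3 to compound 4 (within the scatter), so compound 3 and compound 4 cannot be ordered. Nothing measured here explains these steps.

All the groups shown on this nitrogen are substituted phenyl rings, while the 2-hydroxyphenyl and 2-hydroxy-4-(trifluoromethyl)phenyl groups stay the same throughout. The compounds therefore leave open how a phenyl ring carrying an amine or a carboxylic acid, or a longer alkyl chain in place of the ring, would read in this assay.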